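Swapping a meta methyl for iodine on a dihydropyridine

The source may hold more compounds than are shown below. What is called first, only, known or untested is meant among the compounds shown, and "the series" means these compounds.

Compound 1 `COC(=O)C1=C(C)N=C(C)/C(=C(\O)OC)C1c1cc(Cl)cc(Cl)c1` gives 93.3 nM; compound 2 `COC(=O)C1=C(C)N=C(C)/C(=C(\O)OC)C1c1c(F)c(F)c(F)c(F)c1F` gives 4.37 nM; compound 3 `COC(=O)C1=C(C)N=C(C)/C(=C(\O)OC)C1c1cccc(C)c1` gives 110 nM in a functional assay (muscle tissue) with Cavia porcellus as the target; on this read-out lower numbers stand for an effect already at smaller amounts and higher numbers for an effect only at larger amounts of compound.

Among the three, compound 3 has the highest number in this assay, though only by a 1.2-fold higher number from compound 1 to compound 3 (0.07 log units; within the scatter) from compound 1, while compound 2 sits well below both. Compound 4 `COC(=O)C1=C(C)N=C(C)/C(=C(\O)OC)C1c1cccc(I)c1` differs from compound 3 by iodo in place of methyl on an aromatic carbon. Within the data shown here, the one comparable step, a 1.2-fold higher number from compound 1 to compound 3 (0.07 log units; within the scatter), shows that two chloro groups and a methyl on this ring give similar numbers, so a single iodo is expected to change little. Compound 4 is therefore estimated at 90 nM (range 30 nM to 300 nM), a step of a 1.2-fold lower number from compound 3 to compound 4 (0.09 log units; within the scatter) that is expected to stay within the scatter.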

Compound 4, half-maximal effective concentration: 41.7 nM
The estimate for compound 4 lay 2.2-fold (0.33 log units) above the measured number; the range from low to high includes it.
By their numbers in this assay, from the lowest: compound 2; then compound 4; then compounds 1 and 3 (each within the scatter of the next).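

In this assay the group at this place on the aromatic ring responds to a change of one atom, since iodo in place of methyl gives a 2.6-fold lower number from compound 3 to compound 4 (0.42 log units; beyond the scatter) and so moves beyond the scatter. The 3-iodophenyl group also separates from the 3,5-dichlorophenyl group with a 2.2-fold lower number from compound 1 to compound 4 (0.35 log units; beyond the scatter) even though compound 1 and compound 3 stay within the scatter of each other. Nothing measured here explains this shift. Still open, as far as these compounds go, is how an amine, a carboxylic acid or a longer chain would fare at this same place on the ring.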